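This account rests on a few compounds, and the source may have more. Where it says the series, first, only, none or still open, it means among the compounds named here.

Working notes on the series. Among the compounds with values here, in a functional assay on HFL1 cells (Homo sapiens) for inhibition, read by sulforhodamine B assay, with a stated time of 48 h (on this read-out higher numbers stand for weaker inhibition and lower numbers for stronger inhibition), compound 1 `CC1S/C(=N/N=C/c2cccnc2)NC1=O` gives 830 nM, the only number available so far, so it cannot yet be ranked against anything. Compound 2 `O=C1N=C(Nc2ccc(O)cc2)S/C1=C\C=C/c1ccccc1` offers no comparison, its entry reading "not determined" (no result reported).

The next compound to be read is compound 3 `O=C1CS/C(=N/N=C/c2cccnc2)N1`, which differs from compound 1 in one place: hydrogen in place of methyl on a saturated ring carbon. In words, this is hydrogen in place of methyl on a saturated ring carbon, and the rest of the core of compound 1 is kept.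

Within the data shown here, no measured pair shows what such a change does, so the data give no direction for it. The expectation in this assay is therefore no step beyond the usual scatter, with the value of compound 1 at 830 nM as the sole anchor. The range is kept wide to reflect that single anchor.

The estimated change is a 1.2-fold higher number from compound 1 to compound 3 (0.08 log units; within the scatter). For compound 3 the expected value is 1000 nM, with an estimated range from 300 nM to 3500 nM.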

Compound 3, half-maximal inhibitory concentration in the HFL1 assay: 810 nM
For compound 3 the middle estimate is 1.2-fold (0.09 log units) above the measured one, within the range that was stated.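

In the HFL1 assay, hydrogen in place of methyl on a saturated ring carbon, next to the ring sulfur, gives a 1.0-fold lower number from compound 1 to compound 3 (0.01 log units; within the scatter), so in this pair the read-out keeps its level without the methyl, and this carbon carries either group on the core of compound 1. In a physicochemical assay for inhibition, with a stated time of 3 min (a higher number here means a weaker inhibitor, a lower number a stronger inhibitor), compound 1 gives 1960 nM as its value, but compound 3 is entered as "not determined" (no result reported) there, so the step cannot be read in that assay and the finding rests on the HFL1 assay alone. No measurement is available that bears on why compound 1 and compound 3 read alike.

With only methyl and hydrogen shown at this carbon, it remains open whether an ethyl group, a longer chain, an amine or a carboxylic acid in the same place would also leave the number in the HFL1 assay unchanged. On these data alone, it is also open whether the same swap would read alike on a core other than that of compound 1, or in the physicochemical assay.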